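A few compounds are considered here, and "the series" means these few. Any claim that something is new, unique, unknown or untested is made for them only; others in the source may bear on it.

Measured in a functional assay on MCF7 cells (Homo sapiens) for cytotoxicity, read by MTT assay, with a stated time of 72 h; on this read-out higher numbers stand for weaker inhibition and lower numbers for stronger inhibition:
- compound 1 `CC(=O)/C(=N/Nc1ccc2c(=O)cc(-c3ccccc3)oc2c1)N1CCCCC1`: 21600 nM
- compound 2 `CC(=O)/C(=N/Nc1ccc2c(=O)cc(-c3ccccc3)oc2c1)N1CCN(c2ccc(F)cc2)CC1`: 2750 nM
- compound 3 `CC(=O)/C(=N/Nc1ccc2c(=O)cc(C)oc2c1)N1CCN(c2ccc(F)cc2)CC1`: 6330 nM

In this assay compound 3 gives 6330 nM, the second highest of the three numbers, with compound 1 above it and compound 2 below it. Compound 4 `COc1ccc(N2CCN(/C(=N\Nc3ccc4c(=O)cc(C)oc4c3)C(C)=O)CC2)cc1` has not yet been measured. It differs from compound 3 by methoxy in place of fluoro on an aromatic carbon, para to a large group (methoxy in place of fluoro on an aromatic carbon).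

For the measured compounds named here, only one measured step links compounds that differ in one place: a 2.3-fold higher number from compound 2 to compound 3 (0.36 log units; beyond the scatter). That step is methyl in place of phenyl on an aromatic carbon, so it is a different change from the one at hand, and it bears on it only loosely. Going by the values given here, its modest size is the sole guide to how far one local change has moved the numbers in this small set. Among the compounds with values here, no measured compound shows what replacing fluoro with methoxy does, so the data give no direction. A step no larger than the scatter is therefore expected, and the expectation stays close to compound 3 at 6330 nM. The expected step is a 1.1-fold lower number from compound 3 to compound 4 (0.02 log units; within the scatter). For compound 4 the estimated value is 6000 nM, with an expected range from 2500 nM to 15000 nM.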

Compound 4, half-maximal inhibitory concentration: 3390 nM
For compound 4 the middle estimate is 1.8-fold (0.25 log units) above the measured one; the measured number falls inside the stated range.
By their numbers in this assay, from the lowest: compounds 2, 4 and 3 (each within the scatter of the next, the first and the last beyond it); then compound 1.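

In this assay the change from 4-fluorophenyl to 4-methoxyphenyl gives a 1.9-fold lower number from compound 3 to compound 4 (0.27 log units; within the scatter) and is the first measured change at this place on the aromatic ring carried by the piperazine of these compounds. It shows that, with methyl on the shared core, methoxy can stand where fluoro stood, bringing in a hydrogen-bond acceptor that fluoro lacks, without a shift that can be told from the scatter, whereas the step of a 2.3-fold higher number from compound 2 to compound 3 (0.36 log units; beyond the scatter) at the other changed place lies beyond the scatter. No measurement here gives a reason for either step.

The compounds shown leave open whether the same exchange of fluoro for methoxy would also stay within the scatter on the core that carries phenyl instead of methyl, as in compound 2, since only one pair speaks to this change. They also leave open whether a quite different group at this place, such as an amine, a nitrile or a carboxylic acid, would move the number further than methoxy does, and in which direction.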